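Pyrazoline-thiazoline series: aryl trimming on the imine carbon

The compounds below may be only part of what the source reports. "The series", "measured", "known", "first", "only" and "open" are said of these compounds alone.

Measured compounds:
compound 1 `O=C1CSC(N2N=C(c3ccc(Cl)cc3)CC2c2ccc3ccccc3c2)=N1` — 20400 nM
compound 2 `Cc1ccc(C2=NN(C3=NC(c4ccccc4)CS3)C(c3ccc4ccccc4c3)C2)cc1C` — 7370 nM
compound 3 `Cc1ccc(C2=NN(C3=NC(c4ccccc4)CS3)C(c3cccc4ccccc34)C2)cc1C` — 7250 nM

In a functional assay on HepG2 cells (Homo sapiens) for inhibition, read by CCK-8 assay, with a stated time of 48 h (on this read-out lower numbers stand for stronger inhibition and higher numbers for weaker inhibition), compound 3 gives 7250 nM and stands at the lowest of the three numbers, though its gap to compound 2 is within the scatter: a 1.0-fold lower number from compound 2 to compound 3 (0.01 log units; within the scatter). Only compound 1 is clearly apart; compound 1 differs from compound 3 in more than one place, so its higher number says nothing on its own about any single change.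

Compound 4 `c1ccc(C2=NN(C3=NC(c4ccccc4)CS3)C(c3cccc4ccccc34)C2)cc1` is the next compound to be measured in this assay. It differs from compound 3 as follows: phenyl in place of 3,4-dimethylphenyl on a carbon with a double bond to nitrogen. No measured step bears on this change; the one step shown, from compound 2 to compound 3, concerns the naphthyl group on a saturated ring carbon, not the aryl on the carbon with a double bond to nitrogen. The expectation for compound 4 therefore rests on compound 3 alone, with no pull in either direction beyond the scatter; the change expected is a 1.2-fold higher number from compound 3 to compound 4 (0.09 log units; within the scatter). Compound 4 is thus estimated at 9000 nM, within a range from 3500 nM to 25000 nM.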

Compound 4, half-maximal inhibitory concentration: 13200 nM
Compound 4: middle estimate off by 1.5-fold (0.17 log units), on the low side, and the stated range covers the measured number.
By their numbers in this assay, from the lowest: compounds 3, 2, 4 and 1 (each within the scatter of the next, the first and the last beyond it).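

In this assay, among these compounds, phenyl in place of 3,4-dimethylphenyl on the carbon with a double bond to nitrogen gives a 1.8-fold higher number from compound 3 to compound 4 (0.26 log units; within the scatter), the first measured step at this position, where the earlier compounds offered only a step at the naphthyl group. Within this single pair, the aryl on this carbon can lose both methyl groups without a step beyond the usual scatter, so the two methyl groups are not shown to be needed for the activity read here, though a pair of compounds cannot show what each methyl contributes alone. No measurement at hand offers an explanation for the size of this step.

The chlorine-bearing aryl of compound 1 sits on a compound that differs from the others in more than one place, so it adds nothing on this position, and a single methyl, a methoxy group or a fluorine on the phenyl of compound 4 remains unread. Also open, from the compounds shown here alone, is how an amine or a carboxylic acid on this aryl would read in this assay, and whether the present step holds with naphthalen-2-yl on the saturated ring carbon.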